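The compounds below may be only part of what the source reports. "The series", "measured", "known", "first", "only" and "open" are said of these compounds alone.

Compound 1 `C[S+]([O-])c1c(F)c(N)c2c(=O)cc(-c3ccc(N)c(F)c3)oc2c1F`: 2500 nM. Compound 2 `Nc1ccc(-c2cc(=O)c3c(N)c(F)c(CO)c(F)c3o2)cc1F`: 62 nM.

For the measured compounds named here, in a functional assay on MCF7 cells (Homo sapiens) for cytotoxicity, read by neutral red uptake, with a stated time of 3 days (a lower number here means a stronger inhibitor, a higher number a weaker inhibitor), compound 2 gives the lowest of the two numbers; the single measured step, a 40-fold lower number from compound 1 to compound 2 (1.61 log units; beyond the scatter), was large and lies beyond the scatter. Compound 3 `CN(C)c1c(F)c(N)c2c(=O)cc(-c3ccc(N)c(F)c3)oc2c1F` differs from compound 2 by dimethylamino in place of hydroxymethyl on an aromatic carbon. Going by the values given here, no measured step makes this same exchange, but the one step that alters this position, a 40-fold lower number from compound 1 to compound 2 (1.61 log units; beyond the scatter), shows that a change there can move this assay a long way. Compound 3 is expected to give a higher number, the step of a 6.5-fold higher number from compound 2 to compound 3 (0.81 log units; beyond the scatter) being moderate and uncertain. Compound 3 is estimated at 400 nM, within a range from 80 nM to 2500 nM.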

Compound 3, half-maximal inhibitory concentration: 39 nM
Estimate against measurement, compound 3: 10-fold (1.01 log units) above; measured number outside the range, below it.
By their numbers in this assay, from the lowest: compounds 3 and 2 (each within the scatter of the next); then compound 1.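

In this assay, dimethylamino in place of hydroxymethyl gives a 1.6-fold lower number from compound 2 to compound 3 (0.20 log units; within the scatter), so among these compounds a low number at this position does not require the hydrogen-bond donor of hydroxymethyl. The second step, a 64-fold lower number from compound 1 to compound 3 (1.81 log units; beyond the scatter), joins two groups of equal heavy-atom count, so that count alone does not set the number here. Nothing measured here explains these differences.

The compounds shown leave open whether a primary amine, a carboxylic acid or a longer chain at this position would give a number as low as those of compound 2 and compound 3.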